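From Compound 3 to Its Methylamino Counterpart

The source may report more compounds than this note shows. Statements on the series, on what has been measured and on what is new or still open speak of the compounds shown alone.

Compound 1 `CC1(C)[C@@H](CO)CC[C@@]1(C)Cn1cnc2c(N)ncnc21`: > 200000 nM
Compound 2 `CCOc1ncnc2c1ncn2C[C@@H]1C[C@H](CO)c2ccccc21`: > 200000 nM
Compound 3 `Nc1nc2c(nc(N)n2COCCO)c(=O)[nH]1`: > 200000 nM

All three entries were recorded in an ADME assay on L1210/0 cells (Mus musculus) for cytotoxicity, with a stated time of 48 h (on this read-out lower numbers stand for stronger inhibition and higher numbers for weaker inhibition), and none is a true number. Compound 3 gives > 200000 nM, which is a limit. The same holds for the whole set, which rests on (the limit of > 200000 nM in this assay, at which 3 of the 3 values shown sit). For the measured compounds named here, no pair of measured compounds differs in one place, so no measured step is available as a guide.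

Compound 4 `CNc1nc2c(=O)[nH]c(N)nc2n1COCCO` carries methyl in place of hydrogen on a nitrogen on an aromatic ring, amino to methylamino: methyl in place of hydrogen on a nitrogen on an aromatic ring. No change beyond the scatter is expected in this assay, and no direction can be favoured. The expected size of the change is a number no higher from compound 3 to compound 4 (the limit leaves the size open). Compound 4 is expected at 200000 nM, within an estimated range of 100000 nM to 400000 nM.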

Compound 4, half-maximal inhibitory concentration: > 200000 nM
Compound 4 ended at the assay's limit (the forecaster's own chance of this, stated with the estimate: 85%); the middle value lies on the limit itself.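

Compound 4 gives > 200000 nM in this assay, which is a limit and not a number. Compound 3 stands at the same limit, and the step between compound 3 and compound 4 cannot be read. The compounds shown leave open whether methyl in place of hydrogen changes anything in this read-out, because every value rests on one limit: the limit of > 200000 nM in this assay, at which 4 of the 4 values shown sit.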